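The source may report more compounds than this note shows. Statements on the series, on what has been measured and on what is new or still open speak of the compounds shown alone.

The three measured compounds and their numbers in a functional assay on DU-145 cells (Homo sapiens) for cytotoxicity, read by MTT assay, with a stated time of 48 h; a higher number here means a weaker inhibitor, a lower number a stronger inhibitor:
Compound 1 `COc1ccc(-c2cc(C(=O)Nc3nc4ccc(Cl)cc4s3)nc3cc(-c4ccccc4)nn23)cc1OC` gives 9330 nM.
Compound 2 `COc1ccc(-c2cc(C(=O)Nc3nc4ccc(F)cc4s3)nc3cc(-c4ccccc4)nn23)cc1OC` gives 18600 nM.
Compound 3 `COc1ccc2nc(NC(=O)c3cc(-c4ccc(F)cc4)n4nc(-c5ccccc5)cc4n3)sc2c1` gives 15400 nM.

Compound 3 stands second highest of these three numbers. Its nearest neighbour is compound 2 and its furthest is compound 1, yet both gaps are within the scatter, so the three compounds cannot be told apart on these numbers.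

Compound 4 `COc1ccc2nc(NC(=O)c3cc(-c4ccc(OC)c(OC)c4)n4nc(-c5ccccc5)cc4n3)sc2c1` differs from compound 3 in one place: 3,4-dimethoxyphenyl in place of 4-fluorophenyl on an aromatic carbon. The change sits on the aromatic carbon next to the ring nitrogen of the shared core.

Among the measured compounds shown here, the only step measured so far, a 2.0-fold higher number from compound 1 to compound 2 (0.30 log units; within the scatter), concerns a different position, a fluoro in place of a chloro, and lies within the scatter. For the measured compounds named here, no measured pair shows the exchange of the 4-fluorophenyl for the 3,4-dimethoxyphenyl itself. Still, compound 1 with 9330 nM and compound 2 with 18600 nM already carry the 3,4-dimethoxyphenyl and sit close to compound 3, which suggests that this group on its own does not move the number far. The step is therefore expected to be small, with no direction beyond the scatter: a 1.3-fold lower number from compound 3 to compound 4 (0.11 log units; within the scatter). Compound 4 is estimated at 12000 nM, with a range from 4000 nM to 40000 nM.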

Compound 4, half-maximal inhibitory concentration: 14000 nM
Compound 4: the middle estimate sits 1.2-fold (0.07 log units) below what was measured; measured number inside the range.
By their numbers in this assay, from the lowest: compounds 1, 4, 3 and 2 (each within the scatter of the next).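

In this assay, among the compounds shown here, the exchange of 4-fluorophenyl for 3,4-dimethoxyphenyl on the aromatic carbon next to the ring nitrogen gives a 1.1-fold lower number from compound 3 to compound 4 (0.04 log units; within the scatter) and thus offers the first direct reading of this change: a group with more heavy atoms and two hydrogen-bond acceptors enters, yet the number stays within the scatter. The new compound also opens a second comparison at the aromatic carbon that carries chloro, fluoro or methoxy, where methoxy in place of fluoro gives a 1.3-fold lower number from compound 2 to compound 4 (0.12 log units; within the scatter) and methoxy in place of chloro gives a 1.5-fold higher number from compound 1 to compound 4 (0.18 log units; within the scatter) so that, with the fluoro and chloro compounds already inseparable, none of these three groups can be told apart at this place. Nothing available here explains why these exchanges leave the number within the scatter.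

Every change shown so far stays within the scatter, so it remains unknown whether this position responds to any substituent in this assay. An amine or a carboxylic acid on the phenyl ring at this position would test that, as would a longer chain in place of the methoxy groups.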